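Trimming the Amide Substituent of a Bis-Sulfonamide Piperidine

A few compounds are considered here, and "the series" means these few. Any claim that something is new, unique, unknown or untested is made for them only; others in the source may bear on it.

Compound 2 `CCN(CC)S(=O)(=O)c1ccc(S(=O)(=O)N2CCC[C@@H](C(=O)NC3CN(C(=O)C4CC4)C3)C2)cc1` carries an amide on the shared core whose nitrogen bears a 1-(cyclopropylcarbonyl)azetidin-3-yl group. In a functional assay on MIA PaCa-2 cells (Homo sapiens) for inhibition, read by MTT assay, with a stated time of 3 days (a lower number here means a stronger inhibitor, a higher number a weaker inhibitor), compound 2 gives 3100 nM, the lower of the two measured numbers. The other measured analogue, compound 1 `CCOC(=O)[C@@H]1CCCN(S(=O)(=O)c2ccc(S(=O)(=O)N3CCOCC3)cc2)C1`, gives 4100 nM in this assay, and the two values lie within the usual scatter of each other, so neither compound can be set above the other. Compound 3 `CCN(CC)S(=O)(=O)c1ccc(S(=O)(=O)N2CCC[C@@H](C(=O)NC)C2)cc1` differs from compound 2 in one place: methyl in place of 1-(cyclopropylcarbonyl)azetidin-3-yl on an amide-type nitrogen. Going by the values given here, no step between two measured compounds shows what such a change does here, so the expectation rests on the size of the group that leaves. The expected step is a 2.3-fold higher number from compound 2 to compound 3 (0.35 log units; beyond the scatter), toward a weaker inhibitor, with some chance that only a limit is reported. Compound 3 is therefore estimated at 7000 nM, within a range of 2500 nM to 20000 nM.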

Compound 3, half-maximal inhibitory concentration: 2000 nM
For compound 3 the middle estimate is 3.5-fold (0.54 log units) above the measured one, and the stated range ends above it.
By their numbers in this assay, from the lowest: compounds 3, 2 and 1 (each within the scatter of the next, the first and the last beyond it).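

In this assay, exchanging the 1-(cyclopropylcarbonyl)azetidin-3-yl group for methyl on the amide-type nitrogen gives a 1.6-fold lower number from compound 2 to compound 3 (0.19 log units; within the scatter), so compound 2 and compound 3 cannot be told apart. This first measured step at this position shows that both rings and the carbonyl of the larger group can be replaced by a single methyl with no change that this assay can resolve. Nothing given here explains this result.

Going by these compounds, whether a group of another kind on this nitrogen, such as a 2-aminoethyl chain, a carboxylic acid-bearing chain or a longer n-butyl chain, would move the number beyond the scatter remains open. Compound 1 differs from compound 3 in more than one place, so it does not settle this question.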